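A few compounds are considered here, and "the series" means these few. Any claim that something is new, unique, unknown or untested is made for them only; others in the source may bear on it.

Measured compounds:
compound 1 `COC(C)CO[C@H](CC=C(C)C)C1=CC(=O)c2c(O)ccc(O)c2C1=O` — 53400 nM
compound 2 `CC(C)=CC[C@@H](OC[C@@H](C)O)C1=CC(=O)c2c(O)ccc(O)c2C1=O` — 22500 nM
compound 3 `COCCO[C@H](CC=C(C)C)C1=CC(=O)c2c(O)ccc(O)c2C1=O` — 62400 nM

These three compounds share one core and differ only in the group on a saturated chain carbon bound to an oxygen on a saturated carbon. In a functional assay on HeLa cells (Homo sapiens) for cytotoxicity, read by MTT assay (on this read-out higher numbers stand for weaker inhibition and lower numbers for stronger inhibition), compound 2 gives the lowest of the three numbers; compound 1 stands a 2.4-fold lower number from compound 1 to compound 2 (0.38 log units; beyond the scatter) away, and compound 3 is the furthest, at a 2.8-fold higher number from compound 2 to compound 3 (0.44 log units; beyond the scatter). Compounds 1 and 3 sit within the scatter of each other (a 1.2-fold higher number from compound 1 to compound 3 (0.07 log units; within the scatter)).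

Compound 4 `CCC(CO[C@H](CC=C(C)C)C1=CC(=O)c2c(O)ccc(O)c2C1=O)OC` is not yet measured. It differs from compound 2 in that (1-methoxypropyl in place of 1-hydroxyethyl on a saturated chain carbon bound to an oxygen on a saturated carbon). The measured steps that bear on this are a 2.8-fold higher number from compound 2 to compound 3 (0.44 log units; beyond the scatter) and a 2.4-fold lower number from compound 1 to compound 2 (0.38 log units; beyond the scatter): both times, exchanging the hydroxyl-bearing group of compound 2 for a group without a hydrogen-bond donor raised the number by a modest amount. For the measured compounds named here, compound 4 likewise carries a 1-methoxypropyl group with no hydrogen-bond donor, though no measured pair shows what adding a further chain carbon does. A modest rise in this assay is therefore expected, estimated as a 2.4-fold higher number from compound 2 to compound 4 (0.39 log units; beyond the scatter). Compound 4 is estimated at 55000 nM, with a range from 25000 nM to 120000 nM.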

Compound 4, half-maximal inhibitory concentration: 63500 nM
The estimate for compound 4 lay 1.2-fold (0.06 log units) below the measured number, and the stated range covers the measured number.
By their numbers in this assay, from the lowest: compound 2; then compounds 1, 3 and 4 (each within the scatter of the next).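

With compound 4, a third group without a hydrogen-bond donor stands apart from the hydroxyl-bearing group of compound 2 in this assay, with a 2.8-fold higher number from compound 2 to compound 4 (0.45 log units; beyond the scatter), so among these four compounds only compound 2 has both a hydrogen-bond donor at this position and the lowest number. For the compounds shown here, the new result also adds a test of size that the earlier compounds could not give: neither a 1.0-fold higher number from compound 3 to compound 4 (0.01 log units; within the scatter) nor a 1.2-fold higher number from compound 1 to compound 4 (0.08 log units; within the scatter) lies beyond the scatter, so across the 2-methoxybutyl group of compound 4 and the smaller ether groups of compounds 1 and 3, the extra carbons leave no readable difference. Nothing shown here explains why the hydroxyl-bearing group stands apart from the other three.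

Going by these compounds alone, compound 2 is the only compound here with a hydroxyl at this position, so one example carries the whole contrast, and a 2-hydroxybutyl group would show whether the lower number survives on the longer chain. On these data alone, it also remains open how an amine or a carboxylic acid at this position would read in this assay.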